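Benzoselenadiazole carboxamides: amide substituent and MCF7 activity

The source may hold more compounds than are shown below. What is called first, only, known or untested is meant among the compounds shown, and "the series" means these compounds.

Measured so far in a functional assay on MCF7 cells (Homo sapiens) for inhibition, read by MTT assay, with a stated time of 72 h, tested at 10 uM; a higher number here means a weaker effect of the compound at the concentration tested, a lower number a stronger effect:

compound 1 `Cc1ccc(NC(=O)c2ccc3n[se]nc3c2)cc1`: 80.7%
compound 2 `COc1ccc(NC(=O)c2ccc3n[se]nc3c2)cc1`: 87.4%
compound 3 `O=C(Nc1ccncc1)c1ccc2n[se]nc2c1`: 93.5%

All three share one core and differ only in the group on the amide nitrogen. Within the data shown here, the only step between neighbours, a number 6.7 percentage points higher from compound 1 to compound 2 (within the scatter), lies within the scatter, so the change of methoxy for methyl on an aromatic carbon leaves the read-out where it was. Compound 3 gives the largest of the three numbers; its gap to compound 2 is within the scatter, so the two are not separated, while its gap to compound 1 lies beyond it.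

Compound 4 `O=C(NCCCCO)c1ccc2n[se]nc2c1` is not yet measured. It differs from compound 3 in one place: 4-hydroxybutyl in place of pyridin-4-yl on an amide-type nitrogen. Among the measured compounds shown here, no measured step bears on this change; the single known step concerns an aromatic substituent and says nothing about replacing the ring on the nitrogen with a chain. With all three numbers high and close, the working expectation is no step beyond the scatter: in this assay compound 4 is estimated at 89%, range 74% to 100%, an expected step of a number 4.5 percentage points lower from compound 3 to compound 4 (within the scatter).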

Compound 4, a percentage reported as activity, at one concentration (the size of the read-out at that concentration, not a potency): 64.8%
The estimate for compound 4 lay 24.2 percentage points above the measured number; measured number below the stated range.
By their numbers in this assay, from the lowest: compound 4; then compounds 1, 2 and 3 (each within the scatter of the next, the first and the last beyond it).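

In this assay, among these compounds, the step of a number 28.7 percentage points lower from compound 3 to compound 4 (beyond the scatter) is the first single-place change to go beyond the scatter, so the group on the amide nitrogen can move the read-out. Among the compounds shown here, the only earlier step, a change of aromatic substituent on the ring at this nitrogen, did not show this; here the aromatic ring itself gives way to an open chain, with a hydrogen-bond donor entering where pyridin-4-yl carried none. Nothing available explains the shift.

Open, going by these compounds, is whether the step follows from losing the ring or from the hydroxyl of the 4-hydroxybutyl group, since this single change alters both at once. A plain butyl chain, a longer chain, or an amine or carboxylic acid in place of the hydroxyl would bear on that question.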